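A few compounds are considered here, and "the series" means these few. Any claim that something is new, unique, unknown or untested is made for them only; others in the source may bear on it.

Four compounds share one core. Compound 1 `COc1ccccc1N1CCN(CCCCC(=O)c2cccc(O)c2)CC1`, compound 2 `COc1ccccc1N1CCN(CCCCCC(=O)c2cccc(O)c2)CC1` and compound 3 `COc1ccccc1N1CCN(CCCCC(=O)c2ccccc2O)CC1` have been measured in an assay on isolated protein for binding affinity to 5-hydroxytryptamine receptor 7 (Rattus norvegicus); a lower number here means a stronger inhibitor, a higher number a weaker inhibitor. Compound 1 gives 15 nM, compound 3 gives 16.4 nM, and compound 2 gives 26.8 nM. Compound 2 carries the highest of the three numbers, yet its gap to compound 3 and its gap to compound 1 both sit within the scatter, so no order among the three compounds can be read from these values.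

The unmeasured compound 4 `COc1ccccc1N1CCN(CCCCCC(=O)c2ccccc2O)CC1` differs from compound 2 only in 2-hydroxyphenyl in place of 3-hydroxyphenyl on a carbonyl carbon. The same change has already been measured once within the set: a 1.1-fold higher number from compound 1 to compound 3 (0.04 log units; within the scatter). On that basis the step from compound 2 to compound 4 is expected to stay within the scatter as well, with no clear direction in this assay. Compound 4 is therefore estimated at 29 nM, with a range from 14 nM to 60 nM. The expected shift for compound 4 amounts to a 1.1-fold higher number from compound 2 to compound 4 (0.03 log units; within the scatter).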

Compound 4, inhibition constant: 5.8 nM
Estimate against measurement, compound 4: 5.0-fold (0.70 log units) above; measured number outside the range, below it.
By their numbers in this assay, from the lowest: compound 4; then compounds 1, 3 and 2 (each within the scatter of the next).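

In this assay, 2-hydroxyphenyl in place of 3-hydroxyphenyl on a carbonyl carbon is not neutral on every core: a 4.6-fold lower number from compound 2 to compound 4 (0.66 log units; beyond the scatter). Among the compounds shown here, this modest shift is the only step that lies beyond the scatter. The change therefore does not carry over unchanged from the core of compound 1 to the core of compound 2: the same change on two cores in this assay, a 1.1-fold higher number (0.04 log units; within the scatter) from compound 1 to compound 3 and a 4.6-fold lower number (0.66 log units; beyond the scatter) from compound 2 to compound 4, 5.1-fold (0.70 log units) apart, beyond the scatter of two such steps.

For the compounds shown here, with only two matched pairs, it remains open whether the lower number of compound 4 follows from a general dependence on the core or only from this one combination. A phenyl group without the hydroxyl, a methoxyphenyl group or a longer chain on the same carbonyl carbon would show how far the difference between the two cores extends.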